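This account rests on a few compounds, and the source may have more. Where it says the series, first, only, none or still open, it means among the compounds named here.

Measured so far:
- compound 1, `Cc1ccc(Cl)cc1-c1cc(Nc2ccc(Br)cc2)nc(N)n1`: 34 nM
- compound 2, `Cc1ccc(Br)cc1-c1cc(Nc2ccc(Cl)cc2)nc(N)n1`: 31 nM

Both compounds were measured in an assay on Sf9 cells for inhibition of 1-acyl-sn-glycerol-3-phosphate acyltransferase beta (Homo sapiens); a lower number here means a stronger inhibitor, a higher number a weaker inhibitor. Compound 2 gives the lower of the two numbers, but the gap to compound 1 lies within the scatter of this assay, so no order between them can be read from the data. The two compounds swap their halogens between the two phenyl rings without a change in the number.

Compound 3, `Cc1ccc(Br)cc1-c1cc(Nc2ccc(Br)cc2)nc(N)n1`, has not yet been measured in this assay. It differs from compound 2 by bromo in place of chloro on an aromatic carbon. Going by the values given here, no step between two measured compounds traces this exact change, so no measured size is available for it. Given that compound 1 and compound 2 carry bromo and chloro in either arrangement with numbers within the scatter of each other, the step in this assay is expected to be small, of no fixed direction and not beyond the scatter. Compound 3 is therefore estimated at 30 nM, with a range from 14 nM to 65 nM. The expected step of a 1.0-fold lower number from compound 2 to compound 3 (0.01 log units; within the scatter) is thus close to none.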

Compound 3, half-maximal inhibitory concentration: 18 nM
The estimate for compound 3 lay 1.7-fold (0.22 log units) above the measured number, within the range that was stated.
By their numbers in this assay, from the lowest: compounds 3, 2 and 1 (each within the scatter of the next).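

In this assay, the 4-chlorophenyl to 4-bromophenyl change now has a measured size (a 1.7-fold lower number from compound 2 to compound 3 (0.24 log units; within the scatter)), and bromo in place of chloro on the other halogen-bearing aromatic carbon has one as well (a 1.9-fold lower number from compound 1 to compound 3 (0.28 log units; within the scatter)). Both steps lie within the scatter, so neither halogen site is shown to respond to this exchange, and compounds with bromo at both sites cannot be ranked against those with one chloro. No measurement on hand bears on the reason for these numbers.

The compounds shown carry only chloro and bromo at these two sites, so the effect of fluoro, methoxy or an amine there remains open. Going by these compounds, the contribution of the methyl group and of the amino group on the shared core also remains open.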